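The compounds below may be only part of what the source reports. "The series", "measured", "known", "first", "only" and "open" are said of these compounds alone.

Measured so far in a functional assay on MGC-803 cells (Homo sapiens) for inhibition, read by MTT assay, with a stated time of 72 h; a higher number here means a weaker inhibitor, a lower number a stronger inhibitor:
compound 1 `FC(F)(F)c1ccc(CSc2nc(N3CCNCC3)cc(C(F)(F)F)n2)cc1`: 5870 nM
compound 2 `Cc1csc(Sc2cc(C(F)(F)F)nc(SCc3ccc(C(F)(F)F)cc3)n2)n1`: 21300 nM
compound 3 `FC(F)(F)c1ccc(CSc2nc(Sc3ncccn3)cc(C(F)(F)F)n2)cc1`: 28600 nM

Two of the three numbers cannot be separated: a 1.3-fold higher number from compound 2 to compound 3 (0.13 log units; within the scatter). The third stands apart from this pair, with a 4.9-fold higher number from compound 1 to compound 3 (0.69 log units; beyond the scatter) and a 3.6-fold higher number from compound 1 to compound 2 (0.56 log units; beyond the scatter). Compound 3 therefore sits level with one neighbour and on the weaker side of the other.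

The next structure is compound 4 `FC(F)(F)c1ccc(CSc2nc(Sc3nncs3)cc(C(F)(F)F)n2)cc1`. It carries 1,3,4-thiadiazol-2-yl in place of pyrimidin-2-yl on a sulfur. The same difference reads (pyrimidin-2-yl)sulfanyl to (1,3,4-thiadiazol-2-yl)sulfanyl.

For the measured compounds named here, the one measured exchange of a ring on a sulfur is a 1.3-fold higher number from compound 2 to compound 3 (0.13 log units; within the scatter), and it is the closest precedent. The two larger steps replace piperazin-1-yl on an aromatic carbon, so they bear on this change only weakly. Going by the values given here, no measured compound holds the 1,3,4-thiadiazol-2-yl group, and a single precedent is thin support. No step beyond the scatter is expected in this assay, and no direction can be favoured. The expected change is a 1.2-fold lower number from compound 3 to compound 4 (0.08 log units; within the scatter). The estimated value for compound 4 is 24000 nM. The expected range for compound 4 runs from 11000 nM to 52000 nM.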

Compound 4, half-maximal inhibitory concentration: 10900 nM
Estimate against measurement, compound 4: 2.2-fold (0.34 log units) above; the measured number lies below the stated range.
By their numbers in this assay, from the lowest: compounds 1, 4, 2 and 3 (each within the scatter of the next, the first and the last beyond it).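

In this assay, the exchange of a ring on this sulfur now gives a step beyond the scatter (a 2.6-fold lower number from compound 3 to compound 4 (0.42 log units; beyond the scatter)), whereas the earlier exchange of a ring at the same place stayed within it (a 1.3-fold higher number from compound 2 to compound 3 (0.13 log units; within the scatter)), so the identity of the ring can register in this series. Compound 4 cannot be separated from the 4-methyl-1,3-thiazol-2-yl compound (a 2.0-fold lower number from compound 2 to compound 4 (0.29 log units; within the scatter)) or from the piperazin-1-yl compound (a 1.9-fold higher number from compound 1 to compound 4 (0.27 log units; within the scatter)), so the clear gap to compound 1 seen for compound 2 and compound 3 does not hold for every ring attached through sulfur. No available measurement accounts for the difference between the 1,3,4-thiadiazol-2-yl and pyrimidin-2-yl groups.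

On these data alone, with three rings on the sulfur, it remains open whether a plain phenyl ring there would read with compound 3 or with compound 4. Also open, as far as these compounds go, is whether an amine or a carboxylic acid carried on the 1,3,4-thiadiazol-2-yl ring would move the number beyond the scatter from compound 4, in either direction.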